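This account rests on a few compounds, and the source may have more. Where it says the series, first, only, none or still open, it means among the compounds named here.

Of the compounds shown here, two have so far been tested in an ADME assay on CCRF-CEM cells (Homo sapiens) for cytotoxicity, with a stated time of 72 h; a lower number here means a stronger inhibitor, a higher number a weaker inhibitor. In this assay compound 1 `COc1ccc(-c2cn3nc(Cl)sc3n2)cc1` reaches only the assay limit of > 250000 nM, which is a limit and not a measured number. Compound 2 `Clc1ccc(Cc2nn3c(Br)c(-c4ccc(Cl)cc4)nc3s2)cc1` likewise gives only the limit of > 250000 nM in this assay. Compound 2 therefore stands exactly where every value shown stands, because of the limit of > 250000 nM in this assay, at which 2 of the 2 values shown sit. Compound 3 `Clc1ccc(Cc2nn3c(Br)c(-c4ccc(Cl)cc4Cl)nc3s2)cc1` has not been measured. It differs from compound 2 by chloro in place of hydrogen on an aromatic carbon, in words chloro in place of hydrogen on an aromatic carbon. Going by the values given here, no step between measured compounds exists to guide the expectation, so the estimate rests on the two limits alone. No change beyond the usual scatter is expected from compound 2 to compound 3 in this assay, and the expected step is a number no higher from compound 2 to compound 3 (the limit leaves the size open). Compound 3 is expected to show roughly 250000 nM in this assay, within 100000 nM to 1000000 nM.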

Compound 3, half-maximal inhibitory concentration: 106000 nM
The estimate for compound 3 lay 2.4-fold (0.37 log units) above the measured number; the measured number falls inside the stated range.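

Turning the 4-chlorophenyl of compound 2 into the 2,4-dichlorophenyl of compound 3 places a chloro ortho to a large group and meta to a chloro group, and this single change gives an at least 2.3-fold lower number from compound 2 to compound 3 (0.37 log units; beyond the scatter). This is the first sign that this position on the ring can shift the number in this assay, and compound 3 is the only compound shown to give a measured number rather than a limit: the limit of > 250000 nM in this assay, at which 2 of the 3 values shown sit. From the compounds shown here alone, compound 2 gives only a limit, so the full size of the step remains unknown.

The compounds shown do not tell whether a smaller fluoro, a methyl or an amine at this position would lower the number as well, or leave it unchanged. They also leave open whether the same chloro would have a similar effect on a different core.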